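Swapping trifluoromethyl for nitro: cytotoxicity expectations

The compounds below may be only part of what the source reports. "The series", "measured", "known", "first", "only" and "open" are said of these compounds alone.

Of the compounds shown here, two have been tested in an ADME assay on L929 cells (Mus musculus) for cytotoxicity, read by resazurin assay, with a stated time of 72 h (a higher number here means a weaker inhibitor, a lower number a stronger inhibitor), both built on the same boron-containing core. Compound 1 `O=C(/C=C/c1ccc2c(c1)B(O)OC2)c1ccc(C(F)(F)F)cc1` carries a trifluoromethyl group on its outer aromatic ring. In this assay compound 1 reaches only the limit of the assay, > 10 ug/mL, so no number is known for it. Compound 2 `COc1cccc(C(=O)CCc2ccc3c(c2)B(O)OC3)c1`, a related member of the set, likewise sits at the limit of the assay, > 10 ug/mL. Among the compounds with values here, both results thus share (the limit of > 10 ug/mL in this assay, at which 2 of the 2 values shown sit), and no measured step between two compounds exists to show how a change at the outer ring shifts the reading.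

Compound 3 `O=C(/C=C/c1ccc2c(c1)B(O)OC2)c1ccc([N+](=O)[O-])cc1` differs from compound 1 in one place: nitro in place of trifluoromethyl on an aromatic carbon. Since both measured values are limits rather than numbers, no size for this kind of step has been observed, and the expectation rests only on compound 1 sitting at > 10 ug/mL. The step from compound 1 to compound 3 is expected to be small, none beyond the scatter, with a step that the limit leaves unreadable from compound 1 to compound 3. Compound 3 is therefore estimated at 15 ug/mL, within 5 ug/mL to 50 ug/mL.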

Compound 3, half-maximal inhibitory concentration: > 10 ug/mL
Compound 3 gave a limit, no number (the forecaster's own chance of this, stated with the estimate: 75%); the middle value lies beyond the limit too.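

Compound 1 and compound 3 both end at a limit of the assay rather than a number in this assay, so the swap of trifluoromethyl for nitro yields no readable step: the limit of > 10 ug/mL in this assay, at which 3 of the 3 values shown sit.

The compounds shown leave open where the true value of each lies beyond that limit, and whether this swap changes the reading at all.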